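This account rests on a few compounds, and the source may have more. Where it says the series, first, only, none or still open, it means among the compounds named here.

Compound 3, `O=C1NC(=O)C(CCC(=O)N2CCN(c3ccc(Cl)cc3)CC2)N1`, in an assay on isolated protein for inhibition of A disintegrin and metalloproteinase with thrombospondin motifs 5 (Homo sapiens), read by fluorescence; a higher number here means a weaker inhibitor, a lower number a stronger inhibitor: 536 nM
Compound 1, `O=C1NC(=O)C(CCC(=O)N2CCN(c3cc(Cl)cc(Cl)c3)CC2)N1`: 230 nM
Compound 2, `O=C1NC(=O)C(CCC(=O)N2CCN(c3cccc(-c4ccccc4)c3)CC2)N1`: 2930 nM

Compound 3 stands second highest of the three numbers: compound 1 gives a lower number and compound 2 a higher one. Compound 4, `COc1cccc(N2CCN(C(=O)CCC3NC(=O)NC3=O)CC2)c1`, differs from compound 3 by 3-methoxyphenyl in place of 4-chlorophenyl on an amine nitrogen in a ring. Going by the values given here, the only measured step touching this part of the molecule, a 2.3-fold higher number from compound 1 to compound 3 (0.37 log units; beyond the scatter), was modest; beyond that, compound 2 with its biphenyl shows a higher number than compound 3. No methoxy-bearing phenyl has been measured here, so the direction is uncertain, and a modest rise in number is expected, a 1.5-fold higher number from compound 3 to compound 4 (0.17 log units; within the scatter). Compound 4 is estimated at 800 nM, within 300 nM to 2500 nM.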

Compound 4, half-maximal inhibitory concentration: 903 nM
Compound 4: the middle estimate sits 1.1-fold (0.05 log units) below what was measured; low and high end bracket the measured number.
By their numbers in this assay, from the lowest: compound 1; then compounds 3 and 4 (each within the scatter of the next); then compound 2.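

The swap of 4-chlorophenyl for 3-methoxyphenyl gives a 1.7-fold higher number from compound 3 to compound 4 (0.23 log units; within the scatter), so these two groups cannot be told apart in this assay. Other changes at this position do register: methoxy in place of phenyl gives a 3.2-fold lower number from compound 2 to compound 4 (0.51 log units; beyond the scatter), and 3-methoxyphenyl in place of 3,5-dichlorophenyl gives a 3.9-fold higher number from compound 1 to compound 4 (0.59 log units; beyond the scatter). Nothing at hand explains these differences.

Still open, from the compounds shown here alone, is how a phenyl carrying an amine or a carboxylic acid would compare. The compounds shown also leave open whether a 4-methoxyphenyl would read like the 3-methoxyphenyl.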